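From 2-methylphenyl to 4-methylphenyl at the assay limit

The source may report more compounds than this note shows. Statements on the series, on what has been measured and on what is new or still open speak of the compounds shown alone.

In an ADME assay on a cell-free system (plasma, Mus musculus) for metabolic stability, read by HPLC, with a stated time of 120 min, tested at 2 uM (on this read-out higher numbers stand for a longer-lived compound and lower numbers for a shorter-lived compound), compound 1 `Cc1ccccc1CNC(=O)n1cnc2ccccc21` gives 0.733 h as its half-life. Compound 2 `Cc1ccccc1CNC(=O)n1c(N)nc2ccccc21` reads < 0.0834 h and this is a limit of the assay, not a number. Among the compounds with values here, the one measured step is an at least 8.7-fold lower number from compound 1 to compound 2 (0.94 log units; beyond the scatter) with amino in place of hydrogen on an aromatic carbon. Compound 3 `Cc1ccc(CNC(=O)n2c(N)nc3ccccc32)cc1` keeps that amino and differs from compound 2 by 4-methylphenyl in place of 2-methylphenyl on a saturated chain carbon bound to an amide-type nitrogen with 4-methylphenyl in place of 2-methylphenyl on a saturated chain carbon bound to an amide-type nitrogen. Within the data shown here, no measured step covers this exchange, so no shift beyond the scatter is expected in this assay and the estimated step is a step that the limit leaves unreadable from compound 2 to compound 3 at most in size. For compound 3 the expected half-life is 0.08 h with an estimated range from 0.04 h to 0.25 h as its bounds.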

Compound 3, half-life: < 0.0834 h
Compound 3 gave a limit, no number; the forecaster's own chance of this, stated with the estimate: 70%; the middle value does not contradict the limit.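

Compound 2 and compound 3 each give a limit, not a number, so no step between them can be read: the limit of < 0.0834 h in this assay, at which 2 of the 3 values shown sit.

What the compounds shown leave open is whether 4-methylphenyl and 2-methylphenyl differ at all in half-life once the amino group is present.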